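The source may report more compounds than this note shows. Statements on the series, on what has been measured and on what is new or still open speak of the compounds shown alone.

Working notes on the series. Compound 1 `CCOC(=O)c1ccc(NC(=O)CSC(=S)N[C@H]2CCOC2=O)cc1` carries an ethoxy on the carbonyl carbon of the shared core, and in a functional assay on SMMC-7721 cells (Homo sapiens) for cytotoxicity, read by MTT assay, with a stated time of 72 h (on this read-out higher numbers stand for weaker inhibition and lower numbers for stronger inhibition), compound 1 gives 64900 nM. Compound 2 `O=C(CSC(=S)N[C@H]1CCOC1=O)Nc1ccc(C(=O)/C=C/c2ccc(Cl)cc2)cc1` carries a 2-(4-chlorophenyl)ethenyl on that carbonyl carbon instead. In this assay compound 2 sits at a limit of the assay, > 128000 nM, so no exact number is known for it. The step of an at least 1.9-fold higher number from compound 1 to compound 2 (0.29 log units; that floor lies within the scatter) rests on the limit of > 128000 nM in this assay, at which 1 of the 2 values shown sits, and cannot be sized beyond its floor. Compound 3 `O=C(CSC(=S)N[C@H]1CCOC1=O)Nc1ccc(C(=O)/C=C/c2ccc(F)cc2)cc1` differs from compound 2 only by fluoro in place of chloro on an aromatic carbon. Going by the values given here, no measured step touches a halogen exchange of this kind; the single measured step, from compound 1 to compound 2, concerns the group on the carbonyl carbon and says nothing about the group on the distal aromatic ring. With compound 2 already at the limit, a halogen swap is expected to leave the number where it stands, with no step beyond the scatter. Compound 3 is therefore estimated at 150000 nM in this assay, with a range of 60000 nM to 400000 nM. This estimate for compound 3 means a step that the limit leaves unreadable from compound 2 to compound 3, and a reading that again reports only a limit is expected to be the most likely outcome.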

Compound 3, half-maximal inhibitory concentration: > 128000 nM
Compound 3: a limit, no number; the forecaster's own chance of this, stated with the estimate: 60%; the middle value is on the limit's open side.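

In this assay compound 3 gives > 128000 nM, which is a limit of the assay and not a number. With 2-(4-fluorophenyl)ethenyl in place of ethoxy on the carbonyl carbon, the series shows an at least 1.9-fold higher number from compound 1 to compound 3 (0.29 log units; that floor lies within the scatter), so the replacement now has a second halogen variant on the aromatic carbon, and this floor again lies within the scatter. The step from chloro to fluoro at this position cannot be read, and any difference between the two halogens stays hidden: the limit of > 128000 nM in this assay, at which 2 of the 3 values shown sit.

On these data alone, whether either halogenated ethenyl group truly separates from ethoxy on the carbonyl carbon stays open, as both floors lie within the scatter and neither compound has an exact number. Also open, as far as these compounds go, is what an amine or a carboxylic acid on that aromatic carbon would read in this assay, and whether such a group would bring a value back inside the measurable range, where a step at this position could be sized.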